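Pyrrolyl enones on HeLa cells: furan in place of pyrrole

The source may report more compounds than this note shows. Statements on the series, on what has been measured and on what is new or still open speak of the compounds shown alone.

Measured compounds in a functional assay on HeLa cells (Homo sapiens) for inhibition, read by MTT assay, with a stated time of 48 h; on this read-out higher numbers stand for weaker inhibition and lower numbers for stronger inhibition:
- compound 1, `O=C(/C=C/c1ccccc1)c1ccc[nH]1`: > 100000 nM
- compound 2, `O=C(/C=C/c1ccc([N+](=O)[O-])cc1)c1ccc[nH]1`: 26000 nM
- compound 3, `O=C(/C=C/c1ccc(Cl)cc1)c1ccc[nH]1`: 25000 nM

The value of compound 1 is a limit of this assay, not a number (the limit of > 100000 nM in this assay, at which 1 of the 3 values shown sits). Among the two numbers shown, compound 3 and compound 2 lie within the scatter of each other; the step of a 1.0-fold lower number from compound 2 to compound 3 (0.02 log units; within the scatter) is within the scatter. The steps of an at least 3.8-fold lower number from compound 1 to compound 2 (0.58 log units; beyond the scatter) and an at least 4.0-fold lower number from compound 1 to compound 3 (0.60 log units; beyond the scatter) are both beyond the scatter.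

Compound 4, `O=C(/C=C/c1ccc(Cl)cc1)c1ccco1`, differs from compound 3 by furan-2-yl in place of 1H-pyrrol-2-yl on a carbonyl carbon. Among the compounds with values here, none of the measured steps touches the ring on the carbonyl carbon: all three concern the group on the aromatic carbon of the other ring. Within the data shown here, there is therefore no measured step that bears on this change, and no step beyond the scatter is expected in this assay, with wide uncertainty. The step of no change at the digits printed from compound 3 to compound 4 (within the scatter) is the estimate for compound 4. Compound 4 is expected to give 25000 nM, between 7000 nM and 90000 nM.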

Compound 4, half-maximal inhibitory concentration: 38000 nM
Beside the measured number, compound 4's estimate is 1.5-fold (0.18 log units) below it; the measured number falls inside the stated range.
By their numbers in this assay, from the lowest: compounds 3, 2 and 4 (each within the scatter of the next). At a limit, above all of these: compound 1.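

Within the data shown here, on the ring on the carbonyl carbon, which no earlier step touched, this assay gives the first reading: a 1.5-fold higher number from compound 3 to compound 4 (0.18 log units; within the scatter). In this one pair, with chloro kept on the other ring, the exchange of 1H-pyrrol-2-yl, with its hydrogen-bond donor, for furan-2-yl, with its hydrogen-bond acceptor, gives no step beyond the scatter, so the ring nitrogen and its hydrogen are not needed for a reading of this size. No measurement shown bears on why this step stays within the scatter.

This ring change is shown with chloro alone, so it stays open whether furan-2-yl gives the same reading with nitro or hydrogen on the other ring. Also open, from the compounds shown here alone, is how a thiophen-2-yl ring on the carbonyl carbon, or an amine on the other ring, would read.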